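The source may report more compounds than this note shows. Statements on the series, on what has been measured and on what is new or still open speak of the compounds shown alone.

Compounds with numbers in hand:
compound 1, `CCCC(=O)OCC1CN(C(=O)c2cc(OC)c(OC)c(OC)c2)CCN1C(=O)c1cc(OC)c(OC)c(OC)c1`, 420 nM in a functional assay (Oryctolagus cuniculus) for inhibition of platelet-activating factor receptor (Cavia porcellus); a higher number here means a weaker inhibitor, a lower number a stronger inhibitor
compound 2, `CCCCCC(=O)OCC1CN(C(=O)c2cc(OC)c(OC)c(OC)c2)CCN1C(=O)c1cc(OC)c(OC)c(OC)c1`, 290 nM
compound 3, `CCC(C)(C)NC(=O)OCC1CN(C(=O)c2cc(OC)c(OC)c(OC)c2)CCN1C(=O)c1cc(OC)c(OC)c(OC)c1`, 320 nM

Compound 2 sits at one end of these three numbers, yet neither neighbour is separated from it beyond the scatter: a 1.4-fold lower number from compound 1 to compound 2 (0.16 log units; within the scatter) and a 1.1-fold higher number from compound 2 to compound 3 (0.04 log units; within the scatter). Compound 4, `COc1cc(C(=O)N2CCN(C(=O)c3cc(OC)c(OC)c(OC)c3)C(COC(=O)NC(C)C(C)C)C2)cc(OC)c1OC`, keeps the shared core and differs from compound 2 in one place: (1,2-dimethylpropyl)amino in place of pentyl on a carbonyl carbon. Within the data shown here, the step bearing most directly on this change is the one from compound 2 to compound 3, which likewise replaced pentyl on a carbonyl carbon by a branched alkylamino group, (1,1-dimethylpropyl)amino, and stayed within the scatter; the related replacement of propyl by (1,1-dimethylpropyl)amino, a 1.3-fold lower number from compound 1 to compound 3 (0.12 log units; within the scatter), was also within the scatter. Nothing in hand separates a (1,1-dimethylpropyl)amino from a (1,2-dimethylpropyl)amino group at this position. The expectation for compound 4 is therefore no step beyond the scatter, a 1.1-fold higher number from compound 2 to compound 4 (0.03 log units; within the scatter). Compound 4 is estimated at 310 nM, with a range from 150 nM to 650 nM.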

Compound 4, half-maximal inhibitory concentration: 80 nM
Estimate against measurement, compound 4: 3.9-fold (0.59 log units) above, outside the stated range (below it).
By their numbers in this assay, from the lowest: compound 4; then compounds 2, 3 and 1 (each within the scatter of the next).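

In this assay the group on this carbonyl carbon can move the number beyond the scatter, as seen in a 3.6-fold lower number from compound 2 to compound 4 (0.56 log units; beyond the scatter) and in a 5.3-fold lower number from compound 1 to compound 4 (0.72 log units; beyond the scatter) when (1,2-dimethylpropyl)amino enters. The arrangement of the branched chain matters here: 1,2-dimethylpropyl in place of 1,1-dimethylpropyl on the amide-type nitrogen gives a 4.0-fold lower number from compound 3 to compound 4 (0.60 log units; beyond the scatter) while the nitrogen stays in place, so the nitrogen alone does not produce the gain, and compound 3 also carries it with a 1.1-fold higher number from compound 2 to compound 3 (0.04 log units; within the scatter) as its step. No measurement in hand explains this difference between the two branched chains.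

On these data alone, it remains open whether the gain needs the nitrogen at all, which an ester carrying the same 1,2-dimethylpropyl chain would test. Also open, as far as these compounds go, is how far the branched chain can change, for example to a cyclohexylamino or a 1,3-dimethylbutylamino group.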